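A few compounds are considered here, and "the series" means these few. Any claim that something is new, unique, unknown or untested is made for them only; others in the source may bear on it.

Measured compounds:
- Compound 1, `CC(=O)Nc1nc(-c2cccc(O)c2)cs1`: in a physicochemical assay for solubility, measured as kinetic solubility, with a stated time of 1 h, at pH 7.4 (on this read-out higher numbers stand for higher solubility and lower numbers for lower solubility), compound 1 gives 103000 nM.
- Compound 2, `CC(=O)Nc1nc(-c2nc(C)no2)cs1`: in this assay compound 2 gives 186000 nM.
- Compound 3, `CC(=O)NC1=NN(c2ccc(Cl)c(Cl)c2)CC1`: in this assay compound 3 gives 31000 nM.

Among these three, compound 3 gives the lowest number in this assay. Compound 1 is nearest to it, and compound 2 furthest away; both of those gaps lie beyond the usual scatter of the measurement, so compound 3 is the least soluble of the three measured here. Compound 3 is also the only one of the three with a non-aromatic core, which sets it apart from compound 1 and compound 2.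

Compound 4, `O=C(NC1=NN(c2ccc(Cl)c(Cl)c2)CC1)c1ccnnc1`, is not yet measured. It differs from compound 3 in one place: pyridazin-4-yl in place of methyl on a carbonyl carbon. Among the compounds with values here, no pair of measured compounds here differs in a change of this kind, so there is no measured step to lean on. The expectation for compound 4 is a modest drop in this assay, with the step of a 2.1-fold lower number from compound 3 to compound 4 (0.32 log units; beyond the scatter), though a result within the scatter would not be surprising. Compound 4 is estimated at 15000 nM, within 4000 nM to 60000 nM.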

Compound 4, solubility: 23000 nM
Beside the measured number, compound 4's estimate is 1.5-fold (0.19 log units) below it, and the stated range covers the measured number.
By their numbers in this assay, from the lowest: compounds 4 and 3 (each within the scatter of the next); then compounds 1 and 2 (each within the scatter of the next).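

In this assay, putting pyridazin-4-yl in place of methyl on a carbonyl carbon gives a 1.3-fold lower number from compound 3 to compound 4 (0.13 log units; within the scatter). Compound 3 and compound 4 therefore cannot be told apart on this read-out, even though a six-membered aromatic ring has taken the place of a lone methyl. This single step shows that, for this core, a group much larger than methyl can sit at this position without moving the number beyond the usual scatter, and nothing available explains why the two compounds read alike.

As far as these compounds go, whether a chain carrying an amine or a carboxylic acid at this position would also stay within the scatter remains open. So does whether the same swap would give a similar result on the cores of compound 1 and compound 2.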